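The source may hold more compounds than are shown below. What is called first, only, known or untested is meant among the compounds shown, and "the series" means these compounds.

- compound 1 `Cc1ccccc1CN1CCN(C(=O)CN[C@H]2CCN(S(=O)(=O)Cc3ccccc3)C2)CC1` gives 10200 nM
- compound 2 `Cc1cc(C)c(CN2CCN(C(=O)CN[C@H]3CCN(S(=O)(=O)Cc4ccccc4)C3)CC2)c(C)c1` gives 3300 nM

In a functional assay on K562 cells (Homo sapiens) for cytotoxicity, read by MTT assay, with a stated time of 48 h (on this read-out lower numbers stand for stronger inhibition and higher numbers for weaker inhibition), compound 2 has the lower of the two numbers, at 3300 nM so far. Compound 3 `O=C(CN[C@H]1CCN(S(=O)(=O)Cc2ccccc2)C1)N1CCN(Cc2ccc(Cl)cc2Cl)CC1` differs from compound 2 at one place (2,4-dichlorophenyl in place of 2,4,6-trimethylphenyl on a saturated chain carbon bound to an amine nitrogen in a ring), on a saturated chain carbon bound to an amine nitrogen in a ring. Going by the values given here, the only measured step at this place is a 3.1-fold lower number from compound 1 to compound 2 (0.49 log units; beyond the scatter) and it is modest. Among the compounds with values here, no measured compound carries chlorine, so no clear direction can be read. In this assay the expected step is small, estimated as a 1.2-fold higher number from compound 2 to compound 3 (0.08 log units; within the scatter) and not beyond the scatter. For compound 3 the estimated value is 4000 nM (expected range 1500 nM to 11000 nM).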

Compound 3, half-maximal inhibitory concentration: 4300 nM
For compound 3 the middle estimate is 1.1-fold (0.03 log units) below the measured one, within the range that was stated.
By their numbers in this assay, from the lowest: compounds 2 and 3 (each within the scatter of the next); then compound 1.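

Within this assay the move from methyl groups to chlorines on this benzyl ring reads as a 1.3-fold higher number from compound 2 to compound 3 (0.11 log units; within the scatter) and so shows no real difference between the two groups. Set against the 2-methylphenyl group, the 2,4-dichlorophenyl group gives a 2.4-fold lower number from compound 1 to compound 3 (0.38 log units; beyond the scatter) and so, like 2,4,6-trimethylphenyl, stands apart from it. Nothing available explains either step. Still open, going by these compounds, is whether a plain phenyl ring would fall with these compounds or with compound 1. Also open, on these data alone, is how this position would respond to a ring bearing an amine or a carboxylic acid.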